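The source may hold more compounds than are shown below. What is called first, only, known or untested is meant among the compounds shown, and "the series" means these compounds.

For the measured compounds named here, compound 1, `CC(O)(C(=O)Nc1ccc(S(=O)(=O)c2ccccc2F)cc1)C(F)(F)F`, is the only compound of this small set with a measured number: in a functional assay (Cavia porcellus) with sulfonylurea receptors; K-ATP channels (Homo sapiens) as the target (a lower number here means a stronger inhibitor, a higher number a weaker inhibitor), compound 1 gives 1300 nM. Compound 2, `CC(O)(C(=O)Nc1ccc([N+](=O)[O-])c(S(=O)(=O)c2ccccc2)c1)C(F)(F)F`, is a different case. For compound 2 this assay reports only > 30000 nM, which is a limit of the assay and not a number. The fact that the limit of > 30000 nM in this assay, at which 1 of the 2 values shown sits, means that compound 1 cannot be ranked against compound 2 beyond saying that compound 1 has a measurable number and compound 2 does not.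

Going by the values given here, the untested compound 3, `CC(O)(C(=O)Nc1ccc(S(=O)(=O)c2cncnc2)cc1)C(F)(F)F`, keeps the core of compound 1 and alters only one group. The change is pyrimidin-5-yl in place of 2-fluorophenyl on a sulfonyl sulfur. Among the compounds with values here, no measured pair in this set differs in one place, so there is no directly comparable step to lean on. The expectation is a modest loss of inhibition, a step from compound 1 to compound 3 of about a 2.3-fold higher number from compound 1 to compound 3 (0.36 log units; beyond the scatter), somewhat beyond the usual scatter but not a collapse. On that basis compound 3 is estimated to give 3000 nM in this assay, with a likely range from 1000 nM to 12000 nM.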

Compound 3, half-maximal inhibitory concentration: > 30000 nM
Compound 3: only a limit was reported; the forecaster's own chance of this, stated with the estimate: 10%; middle value at least 10-fold (1.00 log units) from the limit.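

On the sulfonyl sulfur, pyrimidin-5-yl does not stand in for 2-fluorophenyl: in this assay the exchange gives an at least 23-fold higher number from compound 1 to compound 3 (1.36 log units; beyond the scatter). For the compounds shown here, this is the first step in the set between compounds that differ in only one place, and it shows that the group on the sulfonyl sulfur can decide whether a measurable number is obtained at all, something compound 2 could not show, as it differs from compound 1 in more than one place. The true size of the step remains unknown, as the value of compound 3 is a limit of the assay and not a number: the limit of > 30000 nM in this assay, at which 2 of the 3 values shown sit.

The exchange replaces the whole ring, and the compounds shown do not separate the loss of the fluorine atom from the arrival of the ring nitrogens of pyrimidin-5-yl. Going by these compounds, whether a group such as pyridin-3-yl or 2-chlorophenyl on the sulfonyl sulfur would keep a measurable number in this assay remains open.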